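The source may report more compounds than this note shows. Statements on the series, on what has been measured and on what is new or still open speak of the compounds shown alone.

Measured so far:
Compound 1 `CCOc1ccccc1-n1nncc1CN1C(=O)C2(C(C#N)=C(N)Oc3c2c2nc4ccccc4nc2c2ccccc32)c2ccccc21` gives in a functional assay on A549 cells (Homo sapiens) for antiproliferative activity, read by MTT assay, with a stated time of 48 h (a higher number here means a weaker inhibitor, a lower number a stronger inhibitor), the value > 50000 nM, which is a limit of the assay rather than a number.
Compound 2 `N#CC1=C(N)Oc2c(c3nc4ccccc4nc3c3ccccc23)C12C(=O)N(Cc1cnnn1-c1ccc(N)cc1)c1ccccc12` gives in this assay the value > 50000 nM, likewise only a limit.
Compound 3 `N#CC1=C(N)Oc2c(N)cc3nc4ccccc4nc3c2C12C(=O)N(Cc1cnnn1-c1ccccc1Cl)c1ccccc12` gives in this assay the value 29800 nM.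

For the measured compounds named here, compound 3 thus holds the only real number; the other two values sit at the limit of > 50000 nM in this assay, at which 2 of the 3 values shown sit. Compound 4 `Cc1ccc(-n2nncc2CN2C(=O)C3(C(C#N)=C(N)Oc4c(N)cc5nc6ccccc6nc5c43)c3ccccc32)cc1C` differs from compound 3 by 3,4-dimethylphenyl in place of 2-chlorophenyl on an aromatic nitrogen. Going by the values given here, only one measured step exists, a step that the two limits leave unreadable from compound 1 to compound 2, which also exchanges the group on an aromatic nitrogen but cannot be read. Among the compounds with values here, no measured step therefore bears on this change, and no shift beyond the usual scatter is expected. Compound 4 is estimated at 30000 nM, within 10000 nM to 80000 nM, the expected step being a 1.0-fold higher number from compound 3 to compound 4 (0.00 log units; within the scatter).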

Compound 4, half-maximal inhibitory concentration: > 50000 nM
Compound 4 gave a limit, no number; the forecaster's own chance of this, stated with the estimate: 40%; at least 1.6-fold (0.22 log units) between middle value and limit.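

Swapping the group on an aromatic nitrogen now gives a step that can be read, unlike the earlier one: in this assay this change gives an at least 1.6-fold higher number from compound 3 to compound 4 (0.22 log units; that floor lies within the scatter). Going by these compounds, compound 4 gives only a limit, so this is a floor, and the true size of the step stays unknown. Compound 3 remains the only compound with a real number, and most of the set sits at one boundary: the limit of > 50000 nM in this assay, at which 3 of the 4 values shown sit.

On these data alone, whether a phenyl ring carrying an amine or a carboxylic acid at this position would give a lower number than compound 3 stays open. So does whether the chlorine of the 2-chlorophenyl group matters on its own.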